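This account rests on a few compounds, and the source may have more. Where it says the series, first, only, none or still open, it means among the compounds named here.

Working notes on the series. In a functional assay on NCI-H460 cells (Homo sapiens) for antiproliferative activity, read by MTT assay, with a stated time of 48 h (a lower number here means a stronger inhibitor, a higher number a weaker inhibitor), compound 1 `CCCCC1(O)C(=O)Nc2ccc(Nc3ccc(F)cc3)cc21` gives 32500 nM and compound 2 `CCCCCCC1(O)C(=O)Nc2ccc(Nc3ccc(F)cc3)cc21` gives 50700 nM. Within the data shown here, these are the only two numbers so far. Among the measured compounds shown here, the one measured step is a 1.6-fold higher number from compound 1 to compound 2 (0.19 log units; within the scatter), so compound 1 cannot be separated from compound 2 and has no clear rank in this assay.

Compound 3 `CCCCC1(O)C(=O)Nc2ccc(Nc3ccc(C(F)(F)F)cc3)cc21` keeps the chain and the shared core of compound 1. The change is trifluoromethyl in place of fluoro on an aromatic carbon, para to a large group.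

The measured step bears on this only indirectly. For the measured compounds named here, it alters the chain and leaves the fluoro group untouched, and no measured compound carries any other group at that place. The data therefore give no direction for this change, and the working expectation is no shift beyond the scatter in this assay, with a wide margin for the untested substituent.

The step expected is a 1.1-fold lower number from compound 1 to compound 3 (0.03 log units; within the scatter). Compound 3 is expected at 30000 nM, with an estimated range of 10000 nM to 80000 nM.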

Compound 3, half-maximal inhibitory concentration: 12000 nM
Compound 3: the middle estimate sits 2.5-fold (0.40 log units) above what was measured; measured number inside the range.
By their numbers in this assay, from the lowest: compound 3; then compounds 1 and 2 (each within the scatter of the next).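

In this assay, among these compounds, the aromatic carbon para to a large group now answers to a change: the step is a 2.7-fold lower number from compound 1 to compound 3 (0.43 log units; beyond the scatter) and is the first to lie beyond the scatter, though only modestly. The chain change gave a 1.6-fold higher number from compound 1 to compound 2 (0.19 log units; within the scatter) and could not separate its two compounds, so trifluoromethyl in place of fluoro is so far the only change shown to move the number in this assay. No measurement on hand bears on the reason for this step.

Only fluoro and trifluoromethyl are shown at this place, so it remains open whether the step is particular to trifluoromethyl or would also appear with hydrogen, chloro, methoxy or a nitrile on the same carbon. From the compounds shown here alone, it is also open whether trifluoromethyl would give a step of similar size on the longer chain of compound 2, and whether an amine or a carboxylic acid at this place would move the number in the same direction or the opposite one.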